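Benzophenone-linked diaryl ethers: carboxyphenyl swap on the linker

The source may report more compounds than this note shows. Statements on the series, on what has been measured and on what is new or still open speak of the compounds shown alone.

Two measured compounds share the butyl-dioxy linked core. Compound 1 `COc1cc(C(=O)O)ccc1OCCCCOc1ccc(C(=O)CC(C)(C)C)c(O)c1C` in an assay on HEK293 cells for positive allosteric modulation of metabotropic glutamate receptor 2 (Rattus norvegicus), read by thallium flux, with a stated time of 2.5 min (a lower number here means a smaller maximal response, a higher number a larger maximal response), gives 98.6%, while compound 2 `Cc1c(OCCCCOc2ccc(F)c(C(=O)O)c2)ccc(C(=O)CC2CCCC2)c1O` in this assay gives 81%. Compound 2 stands lowest of the two numbers; the nearest, compound 1, lies higher by a gap beyond the usual scatter, though the two differ in more than one place, so no single step can be read from them.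

Compound 3 `Cc1cc(OCCCCOc2ccc(C(=O)CC3CCCC3)c(O)c2C)ccc1C(=O)O` is not yet measured. It differs from compound 2 by one exchange on the linker oxygen: 4-carboxy-3-methylphenyl in place of 3-carboxy-4-fluorophenyl on an oxygen on a saturated carbon. Going by the values given here, no step between measured compounds describes this exchange. Since compound 1, which carries a carboxyl on its linker-side ring, gives 98.6%, a modest rise is expected; the expected step of a number 9 percentage points higher from compound 2 to compound 3 (within the scatter) may still fall within the scatter. Compound 3 is estimated at 90%, with a range of 76% to 104%.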

Compound 3, largest response reached (reported as percent of maximum), in percent of the reference or control that the assay uses: 83.6%
Compound 3: the middle estimate sits 6.4 percentage points above what was measured; the measured number falls inside the stated range.
By their numbers in this assay, from the lowest: compounds 2 and 3 (each within the scatter of the next); then compound 1.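

In this assay, going by these compounds alone, the first single-place exchange, 4-carboxy-3-methylphenyl in place of 3-carboxy-4-fluorophenyl on an oxygen on a saturated carbon, gives a number 2.6 percentage points higher from compound 2 to compound 3 (within the scatter) and so does not separate the two groups. At this position, therefore, two different arrangements of the carboxyl-bearing ring, one carrying fluorine and the other methyl, cannot be told apart by largest response reached. Compound 1 differs from compound 2 and compound 3 in more than one place, so no step to it can be read, and no measurement available here explains the match between the two groups.

Open, going by these compounds, is how a tetrazole or a primary amide in place of the carboxylic acid would read on this ring. Also open, on these data alone, is whether the higher number of compound 1 belongs to its methoxy-bearing ring or to the other end of its structure.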